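This account rests on a few compounds, and the source may have more. Where it says the series, first, only, none or still open, it means among the compounds named here.

Compound 1 `CC(C)Cc1ccc(N2CCC(Oc3cccc4ccc(N)nc34)C2)cc1` gives 1.2 nM in an assay on cells with melanin-concentrating hormone receptor 1 (Homo sapiens) as the target, read by radioligand binding (a higher number here means a weaker inhibitor, a lower number a stronger inhibitor), the lowest of the two numbers recorded here; compound 2 `CNc1ccc2cccc(OC3CCN(c4ccc5c(c4)OCCO5)C3)c2n1` gives 25.6 nM in this assay, a clearly higher number, beyond the scatter. Compound 3 `CC(C)Cc1ccc(N2CCC(Oc3cccc4ccc(NCC5CC5)nc34)C2)cc1` has not yet been measured. It differs from compound 1 by cyclopropylmethyl in place of hydrogen on a nitrogen on an aromatic ring. Going by the values given here, no measured pair carries this change on its own, so its size is not fixed by the numbers in hand. A modest weakening is expected, with a step within the scatter also plausible, giving a 2.5-fold higher number from compound 1 to compound 3 (0.40 log units; beyond the scatter). For compound 3 the estimate is 3 nM, with a range of 0.8 nM to 12 nM.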

Compound 3, half-maximal inhibitory concentration: 149 nM
For compound 3 the middle estimate is 50-fold (1.70 log units) below the measured one; measured number outside the range, above it.
By their numbers in this assay, from the lowest: compound 1; then compound 2; then compound 3.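

On the nitrogen on an aromatic ring, cyclopropylmethyl in place of hydrogen gives a 120-fold higher number from compound 1 to compound 3 (2.09 log units; beyond the scatter) in this assay. Going by these compounds alone, this is the first single-place change, and it shows that this nitrogen is highly sensitive to substitution, with the unsubstituted amino group of compound 1 far better than the (cyclopropylmethyl)amino group. No measurement at hand accounts for the size of this step.

Open, on these data alone, is whether a methyl or ethyl group on this nitrogen brings a step of similar size. Also open, as far as these compounds go, is how a 2-hydroxyethyl chain there would compare.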